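From butylamino to methyl(propyl)amino on a shared core

The source may report more compounds than this note shows. Statements on the series, on what has been measured and on what is new or still open speak of the compounds shown alone.

Within the data shown here, in an ADME assay on the whole organism for inhibition, with Echinochloa crus-galli var. formosensis as the target, with a stated time of 4 days (a lower number here means a stronger inhibitor, a higher number a weaker inhibitor), compound 3 `CCCCNc1nc(Cl)nc(N[C@@H](C)c2ccccc2)n1` gives 12900 nM, the middle of the three numbers measured so far. Compound 1 `CNc1nc(Cl)nc(N[C@@H](C)c2ccccc2)n1` lies higher at 26900 nM, and compound 2 `CC(C)N(c1nc(Cl)nc(N[C@@H](C)c2ccccc2)n1)C(C)C` lies far lower at 110 nM. The next structure, compound 4 `CCCN(C)c1nc(Cl)nc(N[C@@H](C)c2ccccc2)n1`, keeps the shared core and changes only the amino group: methyl(propyl)amino in place of butylamino on an aromatic carbon.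

Two kinds of measured step bear on this change. Lengthening the chain on a monosubstituted amino group moved the number only modestly, with a 2.1-fold lower number from compound 1 to compound 3 (0.32 log units; beyond the scatter). The disubstituted amino group of compound 2 stands apart from both monosubstituted compounds, with a 240-fold lower number from compound 1 to compound 2 (2.39 log units; beyond the scatter) and a 120-fold higher number from compound 2 to compound 3 (2.07 log units; beyond the scatter). Compound 4 is also disubstituted on that nitrogen, so a move to a lower number is expected. Among the measured compounds shown here, compound 2 is the only support for this, and no measured compound carries methyl(propyl)amino, so only part of that gap is expected to carry over. The expected change is a 13-fold lower number from compound 3 to compound 4 (1.11 log units; beyond the scatter), a large step toward a lower number. Compound 4 is estimated at 1000 nM, with an expected range of 150 nM to 6000 nM.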

Compound 4, half-maximal inhibitory concentration: 380 nM
Compound 4: the middle estimate sits 2.6-fold (0.42 log units) above what was measured, and the stated range covers the measured number.
By their numbers in this assay, from the lowest: compound 2; then compound 4; then compound 3; then compound 1.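

In this assay, exchanging butylamino for methyl(propyl)amino gives a 34-fold lower number from compound 3 to compound 4 (1.53 log units; beyond the scatter), so the same atoms joined differently, with 1 hydrogen-bond donor on the leaving group and 0 on the entering one, are enough for a large step at this position. Adding propyl to the nitrogen of compound 1 gives a 71-fold lower number from compound 1 to compound 4 (1.85 log units; beyond the scatter), whereas the propyl extension of the chain in the monosubstituted series gives only a 2.1-fold lower number from compound 1 to compound 3 (0.32 log units; beyond the scatter). The low number of compound 2 is therefore no longer a lone case: a 3.5-fold higher number from compound 2 to compound 4 (0.54 log units; beyond the scatter) leaves a modest gap between the two disubstituted amino groups, and among these four compounds both lie lower than both monosubstituted ones, with none going against this. Nothing measured here explains these steps.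

Dimethylamino and diethylamino would show whether the low numbers hold with shorter chains on that nitrogen, and whether the gap to diisopropylamino follows the branching or the size of the group. Cyclic amines such as pyrrolidine, piperidine and morpholine, which also leave no hydrogen on that nitrogen, remain open as well.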